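This account rests on a few compounds, and the source may have more. Where it says the series, first, only, none or still open, it means among the compounds named here.

Measured so far:

Compound 1, `O=C(/C=C(O)/C=C/c1ccc(O)cc1)c1cc(Cl)ccc1O`, gives 45.3%.
Compound 2, `O=C(C1=C(O)/C(=C/c2ccc(O)cc2)CCC1)c1ccccc1`, gives 34.9%.
Compound 3, `O=C(/C=C(O)/C=C/c1cccc(O)c1)c1cc(Cl)ccc1O`, gives 62.4%.

All three numbers come from an assay on isolated protein for inhibition of Alpha glucosidase (Homo sapiens), with stated times of 5 min and 15 min, tested at 50 uM; on this read-out higher numbers stand for more inhibition at the one concentration tested (going by the name of the read-out) and lower numbers for less inhibition. Compound 1 and compound 3 share a core and differ in one place only: 3-hydroxyphenyl in place of 4-hydroxyphenyl on a double-bonded chain carbon bound to a double-bonded chain carbon. That exchange made a step of a number 17.1 percentage points higher from compound 1 to compound 3 (beyond the scatter), a difference beyond the usual scatter of this assay. Compound 2 has a different core; how it differs from the core of compound 1 is not broken down here, and the two values simply show that compound 2 sits lower than compound 1 and lower still than compound 3 in this assay.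

Compound 4, `O=C(C1=C(O)/C(=C/c2cccc(O)c2)CCC1)c1ccccc1`, has not yet been measured. It stands to compound 2 as compound 3 stands to compound 1: 3-hydroxyphenyl in place of 4-hydroxyphenyl on a double-bonded chain carbon bound to a double-bonded ring carbon. The place is not identical word for word: in the pair compound 1 and compound 3 the carbon carrying the group is bound to a double-bonded chain carbon, while in the pair compound 2 and compound 4 it is bound to a double-bonded ring carbon. It is therefore the same kind of change, not the same change.

An expectation for compound 4 can rest only on this one precedent. The step is expected to be about a number 12.1 percentage points higher from compound 2 to compound 4 (beyond the scatter), set somewhat smaller than the earlier step because a number 17.1 percentage points higher from compound 1 to compound 3 (beyond the scatter) was seen on a different core and a single example is a thin basis. Compound 4 is accordingly estimated at 47%, with a plausible range from 33% to 62% in this assay.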

Compound 4, a percentage reported as inhibition, at one concentration (the size of the read-out at that concentration, not a potency): 43.2%
For compound 4 the middle estimate is 3.8 percentage points above the measured one; measured number inside the range.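

In this assay, putting 3-hydroxyphenyl in place of 4-hydroxyphenyl on the core of compound 2 gives a step of a number 8.3 percentage points higher from compound 2 to compound 4 (within the scatter), so this pair taken alone cannot be told apart. Set beside the same change on the core of compound 1, the new step cannot be called different from the earlier one: the same change on two cores in this assay, a number 17.1 percentage points higher (beyond the scatter) from compound 1 to compound 3 and a number 8.3 percentage points higher (within the scatter) from compound 2 to compound 4, 8.8 percentage points apart, within the scatter of two such steps This fits the idea that the change carries over from one core to the other, but it does not prove it, as only one of the two steps stands clear of the scatter and two pairs are a very small sample.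

Every compound shown carries a hydroxyl on this aromatic ring, so it remains open how a methoxy group, an amine or a carboxylic acid in its stead would read in this assay. Going by these compounds, it also remains open whether the same exchange would give a step of similar size on any further core, and how these percentages at a single concentration would translate into potency.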